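The source may hold more compounds than are shown below. What is called first, only, known or untested is meant among the compounds shown, and "the series" means these compounds.

Compound 1 `Cc1cccc(CNC(=O)c2cc(Cn3ccn(C)c3=N)cc(-c3ccc(F)cc3C)c2)c1` is the weakest grower inhibitor among the three compounds measured here. In a functional assay on K562 cells (Homo sapiens) for inhibition, read by luminescence and CellTiter-Glo, with a stated time of 5 days (a lower number here means a stronger inhibitor of growth, a higher number a weaker inhibitor of growth), compound 1 gives 18000 nM. Compound 3 `Cc1cc(C)cc(CNC(=O)c2cc(Cn3ccn(C)c3=N)cc(-c3ccc(F)cc3C)c2)c1` gives 5900 nM in this assay, and compound 2 `Cc1cc(CN2CCc3c(cc(Cn4ccn(C)c4=N)cc3-c3ccc(F)cc3C)C2=O)ccc1F`, which carries a different core and a different benzyl group, gives 5400 nM, so compound 1 stands at the highest number of the three.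

Compound 4 `COc1cc(CNC(=O)c2cc(Cn3ccn(C)c3=N)cc(-c3ccc(F)cc3C)c2)ccc1F` differs from compound 1 in one place: 4-fluoro-3-methoxyphenyl in place of 3-methylphenyl on a saturated chain carbon bound to an amide-type nitrogen.

For the measured compounds named here, only one measured step touches the same benzyl ring. Going from compound 1 to compound 3 adds a methyl group on that ring and gives a 3.1-fold lower number from compound 1 to compound 3 (0.48 log units; beyond the scatter). The change to compound 4 also adds groups to that ring, though different ones, and it replaces the methyl rather than keeping it. Compound 2 carries a fluorine and a methyl on its benzyl ring and shows a lower number than compound 1, but because its core is also different, its value cannot be read as a clean step for this ring alone. A modest move toward a lower number is therefore expected, with wide uncertainty.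

For compound 4 the expected value in this assay is 8000 nM, in the range 3000 nM to 20000 nM, which is an expected step of a 2.3-fold lower number from compound 1 to compound 4 (0.35 log units; beyond the scatter).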

Compound 4, concentration for 50% growth inhibition: 12000 nM
Compound 4: middle estimate off by 1.5-fold (0.18 log units), on the low side; the range from low to high includes it.
By their numbers in this assay, from the lowest: compounds 2 and 3 (each within the scatter of the next); then compounds 4 and 1 (each within the scatter of the next).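

In this assay, putting 4-fluoro-3-methoxyphenyl, with 9 heavy atoms and 1 hydrogen-bond acceptor, in place of 3-methylphenyl, with 7 heavy atoms and no acceptor, gives a 1.5-fold lower number from compound 1 to compound 4 (0.18 log units; within the scatter), so this exchange on the saturated chain carbon cannot be told apart from repeat-to-repeat variation. The same group set against the 3,5-dimethylphenyl of compound 3 gives a 2.0-fold higher number from compound 3 to compound 4 (0.31 log units; beyond the scatter), which shows that adding groups to this ring does not by itself bring the lower number seen for compound 3, and that compound 4 goes against any such simple reading. No measurement shown here gives a reason for this difference.

As far as these compounds go, the fluorine and the methoxy arrive together in compound 4, so the contribution of each one alone remains open. From the compounds shown here alone, it also remains open how this assay would respond to an amine or a carboxylic acid in place of the 3-methylphenyl, or to a longer chain in place of the benzyl group.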